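The source may hold more compounds than are shown below. What is called first, only, known or untested is meant among the compounds shown, and "the series" means these compounds.

In an ADME assay on J774.1 cells (Mus musculus) for cytotoxicity, read by resazurin assay, with a stated time of 48 h (a lower number here means a stronger inhibitor, a higher number a weaker inhibitor), compound 2 `CCCn1cc(C(=O)NCc2ccc(OC)cc2)c(=O)c2cc(F)c(N3CCC(C(N)=O)CC3)cc21` gives 41400 nM and stands within the scatter of compound 1 `CCCn1cc(C(=O)NCc2ccccc2)c(=O)c2cc(F)c(N3CCC(C(N)=O)CC3)cc21` at 43700 nM so neither ranks over the other. Compound 3 `CCCCn1cc(C(=O)NCc2ccccc2)c(=O)c2cc(F)c(-c3ccccc3)cc21` gives > 100000 nM and this is a limit of the assay and not a number. The move to compound 4 `CCCn1cc(C(=O)NCc2ccco2)c(=O)c2cc(F)c(N3CCC(C(N)=O)CC3)cc21` is furan-2-yl in place of 4-methoxyphenyl on a saturated chain carbon bound to an amide-type nitrogen and amounts to furan-2-yl in place of 4-methoxyphenyl on a saturated chain carbon bound to an amide-type nitrogen. Among the measured compounds shown here, the only measured step on this part of the molecule is a 1.1-fold lower number from compound 1 to compound 2 (0.02 log units; within the scatter) and it gives no sign of sensitivity in this assay here, although replacing the whole ring is a larger change than that step covers. The expected step is a 1.2-fold higher number from compound 2 to compound 4 (0.06 log units; within the scatter) and so no shift beyond the scatter is anticipated in either direction. For compound 4 the estimated value is 48000 nM with 25000 nM and 95000 nM as the expected lower and upper ends.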

Compound 4, half-maximal inhibitory concentration: 56900 nM
Beside the measured number, compound 4's estimate is 1.2-fold (0.07 log units) below it; measured number inside the range.
By their numbers in this assay, from the lowest: compounds 2, 1 and 4 (each within the scatter of the next). At a limit, above all of these: compound 3.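

In this assay, the place on a saturated chain carbon bound to an amide-type nitrogen now shows no step beyond the scatter for a change of the whole ring, not only for a methoxy on it: furan-2-yl in place of 4-methoxyphenyl gives a 1.4-fold higher number from compound 2 to compound 4 (0.14 log units; within the scatter), and furan-2-yl in place of phenyl gives a 1.3-fold higher number from compound 1 to compound 4 (0.11 log units; within the scatter). Compound 1, compound 2 and compound 4 therefore cannot be ranked, even though the five-membered aromatic ring carries fewer heavy atoms than 4-methoxyphenyl. Compound 3 alone sits at a limit, which is not a number: the limit of > 100000 nM in this assay, at which 1 of the 4 values shown sits.

Compound 3 differs from the others in more than one place, so its limit cannot be tied to any single change. As far as these compounds go, whether an amine or a carboxylic acid at this place would give a step beyond the scatter remains open.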